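Series notes: ester and amide variants of a shared core

This account rests on a few compounds, and the source may have more. Where it says the series, first, only, none or still open, it means among the compounds named here.

Measured so far in an ADME assay on MT4 cells (Homo sapiens) for cytotoxicity, read by MTT assay; a higher number here means that more compound is tolerated, a lower number that less compound is tolerated:
compound 1, `COC(=O)c1ccc(NC(=O)CSc2ncncc2-c2cccc3ccccc23)c(Cl)c1`: 155000 nM
compound 2, `CCOC(=O)c1ccc(NC(=O)CSc2ncncc2-c2cccc3ccccc23)c(Cl)c1`: 195000 nM
compound 3, `CCOC(=O)CNC(=O)c1ccc(NC(=O)CSc2ncncc2-c2cccc3ccccc23)c(Cl)c1`: 105000 nM

Compound 1 and compound 2 differ by methyl in place of hydrogen on a saturated chain carbon bound to an oxygen next to a carbonyl group; the step is a 1.3-fold higher number from compound 1 to compound 2 (0.10 log units; within the scatter). Compound 3 differs from compound 1 by ((ethoxycarbonyl)methyl)amino in place of methoxy on a carbonyl carbon, with a 1.5-fold lower number from compound 1 to compound 3 (0.17 log units; within the scatter) and a 1.9-fold lower number from compound 2 to compound 3 (0.27 log units; within the scatter). All three numbers sit close together, so nothing separates them here.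

Compound 4, `CCOC(=O)C(C)NC(=O)c1ccc(NC(=O)CSc2ncncc2-c2cccc3ccccc23)c(Cl)c1`, is not yet measured. It differs from compound 3 by methyl in place of hydrogen on a saturated chain carbon bound to an amide-type nitrogen and a carbonyl carbon. This is the same kind of change as that from compound 1 to compound 2, but not the same: there the methyl enters on a saturated chain carbon bound to an oxygen next to a carbonyl group, here on a saturated chain carbon bound to an amide-type nitrogen and a carbonyl carbon, and the two cores differ by ((ethoxycarbonyl)methyl)amino in place of methoxy on a carbonyl carbon as told above.

For compound 4 the expected step is a 1.2-fold higher number from compound 3 to compound 4 (0.08 log units; within the scatter), set beside a 1.3-fold higher number from compound 1 to compound 2 (0.10 log units; within the scatter); this rests on compound 3 at 105000 nM and on the earlier methyl step having stayed within scatter. Compound 4 is thus estimated at 125000 nM, between 60000 nM and 260000 nM.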

Compound 4, half-maximal cytotoxic concentration: 35600 nM
Compound 4: middle estimate off by 3.5-fold (0.55 log units), on the high side; the whole stated range lies above it.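

In this assay the added methyl does not carry over unchanged from the core of compound 1 to the core of compound 3: the same change on two cores in this assay, a 1.3-fold higher number (0.10 log units; within the scatter) from compound 1 to compound 2 and a 2.9-fold lower number (0.47 log units; beyond the scatter) from compound 3 to compound 4, 3.7-fold (0.57 log units) apart, beyond the scatter of two such steps. The step on the second core is a 2.9-fold lower number from compound 3 to compound 4 (0.47 log units; beyond the scatter) and the wider gaps to the two simple esters are a 5.5-fold lower number from compound 2 to compound 4 (0.74 log units; beyond the scatter) and a 4.4-fold lower number from compound 1 to compound 4 (0.64 log units; beyond the scatter), which leaves the (1-(ethoxycarbonyl)ethyl)amino group as the one variant here that separates from the others. Going by these compounds alone, with only one pair on each core, this shows that the methyl step can differ between these two cores, but not why it differs or how it would behave on any further core.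

From the compounds shown here alone, it remains open whether the lower number belongs to the methyl alone or to the whole ester-bearing chain, which a carboxylic acid in place of the ethyl ester would help to separate. A longer chain in place of the methyl on that same carbon would show whether the step grows with the size of the group.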